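The source may hold more compounds than are shown below. What is called first, only, known or untested is meant among the compounds shown, and "the series" means these compounds.

In a functional assay on CLL cells (Homo sapiens) for cytotoxicity, read by MTT assay, with a stated time of 48 h (on this read-out lower numbers stand for an effect already at smaller amounts and higher numbers for an effect only at larger amounts of compound), three compounds sharing one core have been measured. Compound 1 `C=C(CC)C(=O)c1ccc(OCC(=O)Nc2ccc(S(=O)(=O)O)cc2)c(Cl)c1Cl` gives > 25000 nM, which is a limit of the assay and not a number. Compound 2 `C=C(CC)C(=O)c1ccc(OCC(=O)NC2CCN(CC(=O)OC)CC2)c(Cl)c1Cl` gives 10600 nM, and compound 3 `C=C(CC)C(=O)c1ccc(OCC(=O)Nc2ccc3c(C)cc(=O)oc3c2)c(Cl)c1Cl` gives 2800 nM. Compound 4 `C=C(CC)C(=O)c1ccc(OCC(=O)Nc2ccc(C#N)cc2)c(Cl)c1Cl` has not yet been measured. It carries cyano in place of sulfo on an aromatic carbon, para to a large group (cyano in place of sulfo on an aromatic carbon). The closest guide is compound 3 at 2800 nM, which also has an aromatic ring on the amide nitrogen. A large move toward lower concentrations in this assay is therefore expected, and the estimated step is an at least 6.2-fold lower number from compound 1 to compound 4 (0.79 log units; beyond the scatter). For compound 4 the estimated value is 4000 nM, with an expected range of 1300 nM to 13000 nM.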

Compound 4, half-maximal effective concentration: 7800 nM
The estimate for compound 4 lay 2.0-fold (0.29 log units) below the measured number, and the stated range covers the measured number.
By their numbers in this assay, from the lowest: compound 3; then compounds 4 and 2 (each within the scatter of the next). At a limit, above all of these: compound 1.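

Cyano in place of sulfo, on an aromatic carbon para to a large group, gives an at least 3.2-fold lower number from compound 1 to compound 4 (0.50 log units; beyond the scatter). Among the compounds shown here, the earlier compounds offered no single-place comparison, so this is the only reading of what a change at this position does, and it shows that a replacement there alone can bring a compound off the limit. The true size of the step stays unknown because it starts from a limit: the limit of > 25000 nM in this assay, at which 1 of the 4 values shown sits.

The compounds shown leave open what an amine or a carboxylic acid would give in the same place. They also leave open how cyano would behave elsewhere on that ring.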